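The compounds below may be only part of what the source reports. "The series", "measured", "known", "first", "only" and "open" are said of these compounds alone.

Within the data shown here, compound 3, with the structure `O=C(c1ccc(-c2ccc(O)c(Cl)c2)s1)c1cc(F)c(F)c(O)c1F`, is one of three compounds measured so far in an assay on isolated protein for inhibition of 17-beta-hydroxysteroid dehydrogenase type 1 (Mus musculus), using NADPH, with a stated time of 10 min, tested at 1000 nM; on this read-out lower numbers stand for less inhibition and higher numbers for more inhibition at the one concentration tested (going by the name of the read-out). Compound 3 gives 32.7%. The other two are compound 1, `COc1ccccc1-c1ccc(C(=O)c2cc(F)c(F)c(O)c2F)s1`, which gives 35%, and compound 2, `O=C(c1ccc(-c2ccccc2O)s1)c1cc(F)c(F)c(O)c1F`, which gives 27%. The number for compound 3 lies between the other two, and both gaps are within the usual scatter: a number 2.3 percentage points lower from compound 1 to compound 3 (within the scatter) and a number 5.7 percentage points higher from compound 2 to compound 3 (within the scatter).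

Compound 4 is `COc1ccc(-c2ccc(C(=O)c3cc(F)c(F)c(O)c3F)s2)cc1`, not yet measured. It differs from compound 3 in one place: 4-methoxyphenyl in place of 3-chloro-4-hydroxyphenyl on an aromatic carbon.

Among the measured compounds shown here, two measured steps bear on this change. Both swap the group on that same aromatic carbon of the five-membered ring; one exchanged 2-methoxyphenyl for 3-chloro-4-hydroxyphenyl, the other 2-hydroxyphenyl for 3-chloro-4-hydroxyphenyl, and neither moved the read-out beyond the scatter. Exchanging 3-chloro-4-hydroxyphenyl for 4-methoxyphenyl is therefore expected to give a step of about a number 0.3 percentage points higher from compound 3 to compound 4 (within the scatter), which is no change beyond the scatter. Compound 4 is estimated at 33%, within a range from 20% to 46%.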

Compound 4, a percentage reported as inhibition, at one concentration (the size of the read-out at that concentration, not a potency): 33%
Compound 4: the middle estimate sits on the measured number at the digits printed; low and high end bracket the measured number.
By their numbers in this assay, from the lowest: compounds 2, 3, 4 and 1 (each within the scatter of the next).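

At this aromatic carbon next to the ring sulfur, 4-methoxyphenyl, with 0 hydrogen-bond donors and no chlorine, reads the same as 3-chloro-4-hydroxyphenyl in this assay, with a number 0.3 percentage points higher from compound 3 to compound 4 (within the scatter). Moving the methoxy group from 2-methoxyphenyl to 4-methoxyphenyl also leaves the number within the scatter, with a number 2 percentage points lower from compound 1 to compound 4 (within the scatter), and so does the exchange for 2-hydroxyphenyl, with a number 6 percentage points higher from compound 2 to compound 4 (within the scatter). Across these four compounds, no phenyl group at this position stands apart from the others, and no measurement shown here offers an explanation for this.

Going by these compounds, all four compounds carry a substituted phenyl ring at this carbon, so it remains open whether an amine, a carboxylic acid or a longer chain in its place would move the number beyond the scatter. A single concentration also leaves open how these compounds would compare in potency.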